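The source may hold more compounds than are shown below. What is called first, only, known or untested is meant among the compounds shown, and "the series" means these compounds.

Working notes on the series. In an assay on COS-7 cells for inhibition of patatin-like phospholipase domain-containing protein 2 (Mus musculus), tested at 200 uM (a higher number here means more inhibition at the concentration tested (going by the name of the read-out), a lower number less inhibition), compound 1 `CCOC(=O)c1ccnc(-c2ccc(OCC)cc2)c1` gives 87%, and compound 2 `CCNS(=O)(=O)c1cccc(-c2ccc(OCC)cc2)c1` gives 46%. Compound 2 thus stands lowest of the two numbers in this assay; its nearest neighbour is compound 1, whose number is higher by an amount beyond the scatter. For the measured compounds named here, no step between two measured compounds that differ in one place is available, so nothing measured tells how a single change acts here.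

Compound 3 `CCOc1ccc(-c2cccc(C(=O)N3CCCC3)c2)cc1` is to be measured in this assay. It differs from compound 2 as follows: (pyrrolidin-1-yl)carbonyl in place of ethylsulfamoyl on an aromatic carbon. Compound 1 is not a single-place step from compound 2, so it gives no direct guide to this change.

Expectation: a modest rise from compound 2 to compound 3, a number 12 percentage points higher from compound 2 to compound 3 (beyond the scatter), around the edge of the scatter, with wide uncertainty. Compound 3 is estimated at 58%, range 30% to 85%.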

Compound 3, a percentage reported as inhibition, at one concentration (the size of the read-out at that concentration, not a potency): 53%
Compound 3: middle estimate off by 5 percentage points, on the high side, and the stated range covers the measured number.
By their numbers in this assay, from the lowest: compounds 2 and 3 (each within the scatter of the next); then compound 1.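

In this assay, for the compounds shown here, (pyrrolidin-1-yl)carbonyl in place of ethylsulfamoyl on this aromatic carbon gives a number 7 percentage points higher from compound 2 to compound 3 (within the scatter), the first single-place step at this position, and it shows no change beyond the scatter. The exchange removes the sulfur and the hydrogen-bond donor of ethylsulfamoyl and brings in a five-membered non-aromatic ring, yet the two numbers stay within the scatter of each other, so this position accepts both groups alike in this read-out. No measurement on hand bears on the cause of this result.

On these data alone, whether a carboxylic acid, an amine or a longer chain on this aromatic carbon would move the number remains open. Also open, as far as these compounds go, is whether an ethyl ester at this place on the core of compound 2 would give a different number.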